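Replacing 2-methylphenyl with phenethyl on a carbonyl carbon

A few compounds are considered here, and "the series" means these few. Any claim that something is new, unique, unknown or untested is made for them only; others in the source may bear on it.

In a functional assay on SW 1116 cells (Homo sapiens) for antiproliferative activity, read by MTT assay, with a stated time of 48 h (on this read-out lower numbers stand for an effect already at smaller amounts and higher numbers for an effect only at larger amounts of compound), compound 1 `O=C(Nc1nnc(-c2ccc3c(c2)OCCO3)s1)c1ccccc1` gives 67.6 ug/mL. Compound 2 `Cc1ccccc1C(=O)Nc1nnc(-c2ccc3c(c2)OCCO3)s1` gives > 100 ug/mL, which is a limit of the assay and not a number. For the measured compounds named here, the only measured step, methyl in place of hydrogen on an aromatic carbon, is an at least 1.4-fold higher number from compound 1 to compound 2 (0.17 log units; that floor lies within the scatter). Compound 3 `O=C(CCc1ccccc1)Nc1nnc(-c2ccc3c(c2)OCCO3)s1` differs from compound 2 by phenethyl in place of 2-methylphenyl on a carbonyl carbon. Going by the values given here, that measured step bears on this change only loosely, since its methyl belongs to the group that leaves, and no step yet tests phenethyl. A small step towards a lower number is therefore expected in this assay, though it may not go beyond the scatter. The expected change is an at least 1.2-fold lower number from compound 2 to compound 3 (0.09 log units; that floor lies within the scatter). For compound 3, the estimate is 80 ug/mL, with an expected range from 35 ug/mL to 180 ug/mL.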

Compound 3, half-maximal effective concentration: 16.2 ug/mL
The estimate for compound 3 lay 4.9-fold (0.69 log units) above the measured number, and the stated range ends above it.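

In this assay, the group on the carbonyl carbon can shift the read-out beyond the scatter, which the earlier methyl step could not show: phenethyl in place of 2-methylphenyl gives an at least 6.1-fold lower number from compound 2 to compound 3 (0.79 log units; beyond the scatter) at this place. Phenethyl in place of phenyl, a comparison between two measured numbers, gives a 4.2-fold lower number from compound 1 to compound 3 (0.62 log units; beyond the scatter) and so confirms the shift without relying on a limit. The first of these steps is only a floor, because compound 2 stands at a limit of the assay and not at a number: the limit of > 100 ug/mL in this assay, at which 1 of the 3 values shown sits.

The compounds shown leave open whether the lower number belongs to the chain or to the aromatic ring it carries, as phenethyl is the only such group here. A benzyl group, a longer phenylpropyl chain or a plain hexyl chain on the same carbonyl carbon would help to separate the two.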